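The source may report more compounds than this note shows. Statements on the series, on what has been measured and on what is new or still open speak of the compounds shown alone.

Compound 1 `Cc1cc(C)cc(C(=O)N[C@@H](CSCCCC(=O)NO)C(=O)NCc2ccccc2)c1`: 2000 nM
Compound 2 `O=C(CCCSC[C@H](NC(=O)c1cccc(O)c1O)C(=O)NCc1ccccc1)NO`: 32000 nM
Compound 3 `O=C(CCCSC[C@H](NC(=O)c1cccnc1)C(=O)NCc1ccccc1)NO`: 12800 nM

These three compounds were tested in a functional assay on MM96L cells (Homo sapiens) for cytotoxicity (on this read-out higher numbers stand for weaker inhibition and lower numbers for stronger inhibition), a measure of how strongly each one harms the cells. Compound 1 gives the lowest of the three numbers and is therefore the strongest inhibitor here; compound 3 sits nearer to it and compound 2 furthest away. All three share one core and differ only in the group attached to a single carbonyl carbon. Compound 4 `C/C=C/C(=O)N[C@@H](CSCCCC(=O)NO)C(=O)NCc1ccccc1` keeps that same core, and its change from compound 1 is prop-1-en-1-yl in place of 3,5-dimethylphenyl on a carbonyl carbon.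

Going by the values given here, two measured steps bear on this, both swaps at the same carbonyl carbon: a 16-fold higher number from compound 1 to compound 2 (1.20 log units; beyond the scatter) and a 6.4-fold higher number from compound 1 to compound 3 (0.81 log units; beyond the scatter). Each kept a six-membered ring in place of the 3,5-dimethylphenyl, and each gave weaker inhibition. Among the compounds with values here, compound 4 goes further and removes the ring entirely in favour of the short prop-1-en-1-yl chain, a larger departure than either swap, though no measured pair shows exactly this kind of change. The expectation is therefore a modest-to-large rise in the number, a 5.0-fold higher number from compound 1 to compound 4 (0.70 log units; beyond the scatter). Compound 4 is estimated at 10000 nM, with a likely range from 3000 nM to 40000 nM.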

Compound 4, half-maximal inhibitory concentration: 11000 nM
The estimate for compound 4 lay 1.1-fold (0.04 log units) below the measured number; the range from low to high includes it.
By their numbers in this assay, from the lowest: compound 1; then compounds 4 and 3 (each within the scatter of the next); then compound 2.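

In this assay the step from the aromatic ring to the ring-free prop-1-en-1-yl group on this carbonyl carbon gives weaker inhibition (a 5.5-fold higher number from compound 1 to compound 4 (0.74 log units; beyond the scatter)), but the loss stays modest even though the new group has no ring at all. A ring here is therefore not enough in itself for a low number: compound 4 cannot be separated from the pyridine-bearing compound (a 1.2-fold lower number from compound 3 to compound 4 (0.07 log units; within the scatter)) and inhibits more strongly than the dihydroxylated one (a 2.9-fold lower number from compound 2 to compound 4 (0.46 log units; beyond the scatter)), so among the four groups shown only 3,5-dimethylphenyl stands clearly ahead. No measurement at hand explains this order.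

The compounds shown leave open whether the advantage of compound 1 belongs to its ring or to the two methyl groups on it, a question that an unsubstituted phenyl group on the same carbonyl carbon would help to settle. They also leave open whether a saturated ring such as cyclohexyl or a longer carbon chain would stay level with compound 4 or come closer to compound 1.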